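This account rests on a few compounds, and the source may have more. Where it says the series, first, only, none or still open, it means among the compounds named here.

Series notes. Compound 1 `COc1cccc(N2C(=O)CS/C2=N\c2csc(-c3ccc(Cl)cc3)c2)c1` is measured in a functional assay on MCF7 cells (Homo sapiens) for cytotoxicity, read by MTT assay, with a stated time of 72 h (on this read-out higher numbers stand for weaker inhibition and lower numbers for stronger inhibition), only as a limit of that assay: compound 1 gives > 50000 nM. Within the data shown here, the one measured neighbour so far is compound 2 `CN(C)c1ccc(N2C(=O)CS/C2=N\c2csc(-c3ccc(Cl)cc3)c2)cc1`, which carries 4-(dimethylamino)phenyl in place of 3-methoxyphenyl on the amide-type nitrogen in the ring. In this assay compound 2 likewise returns only a limit, > 50000 nM. The step that the two limits leave unreadable from compound 1 to compound 2 therefore cannot be sized, and the only fixed point on the numbers is the limit of > 50000 nM in this assay, at which 2 of the 2 values shown sit. Compound 3 `COc1ccc(N2C(=O)CS/C2=N\c2csc(-c3ccc(Cl)cc3)c2)cc1OC` differs from compound 1 by methoxy in place of hydrogen on an aromatic carbon. Among the measured compounds shown here, no measured step bears on this change in a readable way, so no direction can be taken from the numbers; the expectation for compound 3 rests on (the limit of > 50000 nM in this assay, at which 2 of the 2 values shown sit). The estimated step that the limit leaves unreadable from compound 1 to compound 3 is expected to be none beyond the scatter. In this assay compound 3 is expected at 60000 nM, with a range of 15000 nM to 250000 nM.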

Compound 3, half-maximal inhibitory concentration: 18700 nM
Compound 3: middle estimate off by 3.2-fold (0.51 log units), on the high side, and the stated range covers the measured number.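

In this assay, methoxy in place of hydrogen on an aromatic carbon, ortho to a methoxy group and para to a large group, gives an at least 2.6-fold lower number from compound 1 to compound 3 (0.42 log units; beyond the scatter), so this position on the ring can move the read-out towards stronger inhibition. Among these compounds, this is the first readable change, and it is readable only in direction and minimum size, as the starting point, compound 1, is a limit of the assay. Compound 3 is the only one of the three compounds shown with a number rather than a limit: the limit of > 50000 nM in this assay, at which 2 of the 3 values shown sit.

As far as these compounds go, whether a chlorine, a hydroxyl or an amine at this position would also lower the number stays open. So does whether the added methoxy would do so without the methoxy group already on the ring.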